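A few compounds are considered here, and "the series" means these few. Any claim that something is new, unique, unknown or untested is made for them only; others in the source may bear on it.

Measured so far in a functional assay on HOS-TE85 cells (Homo sapiens) for inhibition, read by CCK-8 assay, with a stated time of 72 h, tested at 1 uM; a lower number here means less inhibition, a higher number more inhibition at the concentration tested (going by the name of the read-out): compound 1 `COc1ccc(C)cc1N1C(=O)CSC1c1cccc(C(=O)NCCCCc2ccccc2)c1` with 95%; compound 2 `COc1ccc(OC)c(N2C(=O)CSC2c2cccc(C(=O)NCCCCc3ccccc3)c2)c1` with 20%; compound 3 `COc1ccc(F)cc1N1C(=O)CSC1c1cccc(C(=O)NCCCCc2ccccc2)c1` with 95%.

Compound 3 stands level with compound 1, the two together at the top of these three numbers, and far ahead of compound 2. Compound 4 `O=C(NCCCCc1ccccc1)c1cccc(C2SCC(=O)N2c2ccccc2)c1` is not yet measured; its change from compound 3 is phenyl in place of 5-fluoro-2-methoxyphenyl on an amide-type nitrogen in a ring. Two kinds of measured step bear on this. Exchanging methyl for fluoro left the number where it was, no change at the digits printed from compound 1 to compound 3 (within the scatter). Putting methoxy in that same place instead cost a great deal, a number 75 percentage points lower from compound 1 to compound 2 (beyond the scatter), and reversing it regained as much, a number 75 percentage points higher from compound 2 to compound 3 (beyond the scatter). Among the compounds with values here, no measured step removes the methoxy that all three compounds carry, so that part of the change is untested. Compound 4 is therefore expected to come in somewhat lower, a number 25 percentage points lower from compound 3 to compound 4 (beyond the scatter). Compound 4 is estimated at 70%, between 30% and 95%.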

Compound 4, a percentage reported as inhibition, at one concentration (the size of the read-out at that concentration, not a potency): 96%
The estimate for compound 4 lay 26 percentage points below the measured number; measured number outside the range, above it.
By their numbers in this assay, from the lowest: compound 2; then compounds 1, 3 and 4 (each within the scatter of the next).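

The plain phenyl on the ring nitrogen does as well as the substituted rings in this assay (a number 1 percentage points higher from compound 3 to compound 4 (within the scatter); a number 1 percentage points higher from compound 1 to compound 4 (within the scatter)), so among these compounds the methoxy and the second substituent are not needed for a high number. Compound 2 alone falls away, its 2,5-dimethoxyphenyl giving way to phenyl with a large gain (a number 76 percentage points higher from compound 2 to compound 4 (beyond the scatter)), which places the loss in that particular ring pattern. Nothing measured here explains that loss.

Open, on these data alone, is whether an amine or a carboxylic acid on this phenyl would keep the number. Also open, as far as these compounds go, is whether a 3-methoxyphenyl or a 4-methoxyphenyl would behave like compound 2 or like compound 4.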